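A few compounds are considered here, and "the series" means these few. Any claim that something is new, unique, unknown or untested is made for them only; others in the source may bear on it.

Within the data shown here, compound 1, `CCCCC(=O)Nc1ccn([C@@H]2CO[C@H](CO)O2)c(=O)n1`, is an amide of the shared core, and in a functional assay on SW1573 cells (Homo sapiens) for cytotoxicity, read by sulforhodamine B assay, with a stated time of 72 h (on this read-out lower numbers stand for stronger inhibition and higher numbers for weaker inhibition), compound 1 gives 9130 nM, the higher of the two numbers known here. Compound 2, `CCCCCCCCCCCCCCCCCCCC(=O)Nc1ccn([C@@H]2CO[C@H](CO)O2)c(=O)n1`, carries a much longer chain on the same carbonyl, and in this assay compound 2 gives 150 nM, a gap that lies beyond the scatter. Compound 3, `O=C(Nc1ccn([C@@H]2CO[C@H](CO)O2)c(=O)n1)c1ccc(Br)cc1`, differs from compound 1 in one place: 4-bromophenyl in place of butyl on a carbonyl carbon. Among the measured compounds shown here, no measured pair shows this exact change, so the expected step is a 3.0-fold lower number from compound 1 to compound 3 (0.48 log units; beyond the scatter), toward a lower number but with wide doubt. For compound 3 the estimate is 3000 nM, within 700 nM to 13000 nM.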

Compound 3, half-maximal inhibitory concentration: 8870 nM
Estimate against measurement, compound 3: 3.0-fold (0.47 log units) below, and the stated range covers the measured number.
By their numbers in this assay, from the lowest: compound 2; then compounds 3 and 1 (each within the scatter of the next).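

Placing 4-bromophenyl in place of butyl on a carbonyl carbon gives a 1.0-fold lower number from compound 1 to compound 3 (0.01 log units; within the scatter) in this assay, so a ring bearing bromine and a short chain read alike here. Changing the group at this position therefore need not shift the number, although compound 2, with its much longer chain, gives 150 nM. Nothing measured here offers a reason for this match. From the compounds shown here alone, it remains open whether a plain phenyl ring would read the same, and whether an octyl chain would resemble butyl or the long chain of compound 2.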